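The source may hold more compounds than are shown below. What is called first, only, known or untested is meant among the compounds shown, and "the series" means these compounds.

Compound 1 `COc1ccc(C(=O)c2ccc3c(ccn3S(=O)(=O)c3ccc(/C=C/C(=O)NO)cc3)c2)cc1` gives in an assay on isolated protein for inhibition of polyamine deacetylase HDAC10 (Homo sapiens) (on this read-out lower numbers stand for stronger inhibition and higher numbers for weaker inhibition), a value of > 100000 nM, which is a limit of the assay rather than a number. Compound 2 `O=C(NO)c1ccc(Cn2ccc3cc(C(=O)c4ccc(F)cc4)ccc32)cc1` gives in this assay > 100000 nM, likewise a limit of the assay.

Within the data shown here, compound 2 therefore stands at the edge of what the measurement can report, and so does the one other compound: the limit of > 100000 nM in this assay, at which 2 of the 2 values shown sit. Compound 3 `Cc1ccc(C(=O)c2ccc3c(ccn3Cc3ccc(C(=O)NO)cc3)c2)cc1` differs from compound 2 by methyl in place of fluoro on an aromatic carbon. Among the measured compounds shown here, with no measured step to draw on, no change beyond the usual scatter is expected in this assay. The step expected is a step that the limit leaves unreadable from compound 2 to compound 3. For compound 3 the estimated value in this assay is 150000 nM, in a range from 50000 nM to 500000 nM, most probably again reported only as a limit.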

Compound 3, half-maximal inhibitory concentration: > 100000 nM
Compound 3: no number, only a limit (the forecaster's own chance of this, stated with the estimate: 80%); the middle value does not contradict the limit.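

Among these compounds, compound 2 and compound 3 both give only a limit of the assay, so no step between them can be read. The compounds shown leave open whether any change to the shared core gives a measurable value in this assay.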